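This account rests on a few compounds, and the source may have more. Where it says the series, first, only, none or still open, it means among the compounds named here.

Compound 3 `O=c1oc2ccccc2n1CCCN1Cc2ccccc2C1` stands at the weak end of what has been measured: in an assay on Jurkat cells for displacement of a labelled ligand from Sigma non-opioid intracellular receptor 1 (Homo sapiens), read by scintillation counting, with a stated time of 120 min (on this read-out lower numbers stand for stronger inhibition and higher numbers for weaker inhibition), compound 3 gives only a limit, > 100 nM, rather than a number. That is the limit of > 100 nM in this assay, at which 1 of the 3 values shown sits, of the assay. For comparison, compound 1 `CN(CCCn1c(=O)oc2cc(Br)ccc21)Cc1ccccc1` gives 0.9 nM in this assay, and compound 2 `CN(CCCn1c(=O)sc2ccc(Cl)cc21)Cc1ccccc1` gives 4.7 nM. Compound 4 `O=c1oc2cc(Br)ccc2n1CCCN1Cc2ccccc2C1` differs from compound 3 by bromo in place of hydrogen on an aromatic carbon, a bromo in place of hydrogen on an aromatic carbon. For the measured compounds named here, no step between two measured compounds that differ in a single place is available, so the size of this change cannot be read off directly. Compound 1 carries a bromo on the shared core and gives 0.9 nM, which makes a gain in binding plausible. Compound 4 is therefore expected to give 60 nM, within 15 nM to 300 nM, a step from compound 3 estimated as an at least 1.6-fold lower number from compound 3 to compound 4 (0.22 log units; that floor lies within the scatter).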

Compound 4, inhibition constant: > 100 nM
Compound 4 ended at the assay's limit (the forecaster's own chance of this, stated with the estimate: 35%); middle value at least 1.6-fold (0.22 log units) from the limit.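

Compound 3 and compound 4 both end at a limit of the assay, so no step between them can be read: the limit of > 100 nM in this assay, at which 2 of the 4 values shown sit.

The compounds shown leave open whether bromo in place of hydrogen changes binding at all.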